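A few compounds are considered here, and "the series" means these few. Any claim that something is new, unique, unknown or untested is made for them only; others in the source may bear on it.

Measured compounds:
- compound 1, `Nc1cc(N)c2nc(-c3ccccc3)c(Sc3ccc(F)cc3)nc2c1`, 38000 nM
- compound 2, `COc1cc(CNc2nc3cc(N)cc(N)c3nc2-c2ccccc2)cc(OC)c1OC`, 15100 nM

Both were tested in a functional assay on MDA-MB-231 cells (Homo sapiens) for inhibition, read by sulforhodamine B assay, with a stated time of 48 h; a higher number here means a weaker inhibitor of growth, a lower number a stronger inhibitor of growth. Compound 1 has the higher of the two numbers: compound 2 gives a lower number, and the gap between them is beyond the scatter of repeated measurements, so compound 2 is the stronger inhibitor of growth of the two.

Compound 3, `COc1ccc(Sc2nc3cc(N)cc(N)c3nc2-c2ccccc2)cc1`, has not yet been measured. It differs from compound 1 in one place only: methoxy in place of fluoro on an aromatic carbon. For the measured compounds named here, no measured pair shows this exact change, so its effect can only be guessed. The change is small, and nothing in the two measured compounds points toward either direction. The expected step of a 1.2-fold lower number from compound 1 to compound 3 (0.07 log units; within the scatter) is therefore not beyond the scatter. Compound 3 is expected to give about 32000 nM, with a range from 12000 nM to 85000 nM.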

Compound 3, concentration for total growth inhibition: < 100000 nM
Compound 3: no number, only a limit; the forecaster's own chance of this, stated with the estimate: 10%; the middle value lies beyond the limit too.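

In this assay, for the compounds shown here, compound 3 gives only a limit, < 100000 nM, and not a number, so no step between compound 1 and compound 3 can be read. Going by these compounds, whether methoxy in place of fluoro on an aromatic carbon changes growth inhibition, and in which direction, stays open.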